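Swapping bromo for tert-butyl: what to expect

The compounds below may be only part of what the source reports. "The series", "measured", "known", "first", "only" and "open" are said of these compounds alone.

Measured compounds in a functional assay on HeLa cells (Homo sapiens) for cytotoxicity, read by MTT assay, with a stated time of 48 h; a lower number here means a stronger inhibitor, a higher number a weaker inhibitor:
Compound 1, `O=c1ccoc2cc(OCc3cn(Cc4ccc(Cl)cc4)nn3)ccc12`, gives 37600 nM.
Compound 2, `O=c1ccoc2cc(OCc3cn(Cc4ccc(F)cc4)nn3)ccc12`, gives 12000 nM.
Compound 3, `O=c1ccoc2cc(OCc3cn(Cc4ccc(Br)cc4)nn3)ccc12`, gives > 100000 nM, which is a limit of the assay and not a number.

Compound 3 thus stands at the weak end of the three, known only through (the limit of > 100000 nM in this assay, at which 1 of the 3 values shown sits). The measured steps are all halogen swaps on the same aromatic carbon: a 3.1-fold lower number from compound 1 to compound 2 (0.50 log units; beyond the scatter), an at least 2.6-fold higher number from compound 1 to compound 3 (0.42 log units; beyond the scatter) and an at least 8.3-fold higher number from compound 2 to compound 3 (0.92 log units; beyond the scatter). Compound 4, `CC(C)(C)c1ccc(Cn2cc(COc3ccc4c(=O)ccoc4c3)nn2)cc1`, differs from compound 3 by tert-butyl in place of bromo on an aromatic carbon. Among the compounds with values here, no measured step involves tert-butyl, so these halogen steps bear on it only loosely. Since the number rose from compound 2 through compound 1 to compound 3 as the group grew, compound 4 is expected to remain weak, estimated at 100000 nM, between 30000 nM and 300000 nM, a step of a number no higher from compound 3 to compound 4 (the limit leaves the size open).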

Compound 4, half-maximal inhibitory concentration: 17600 nM
Compound 4: middle estimate off by 5.7-fold (0.75 log units), on the high side, outside the stated range (below it).
By their numbers in this assay, from the lowest: compounds 2 and 4 (each within the scatter of the next); then compound 1. At a limit, above all of these: compound 3.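

At this position, the rise in the number from fluoro through chloro to bromo does not continue to the larger tert-butyl group: compound 4 goes against it, with an at least 5.6-fold lower number from compound 3 to compound 4 (0.75 log units; beyond the scatter). Beside the other two halogens, the change shows a 1.5-fold higher number from compound 2 to compound 4 (0.17 log units; within the scatter) and a 2.1-fold lower number from compound 1 to compound 4 (0.33 log units; beyond the scatter), so compound 4 sits with the fluoro compound rather than the bromo one. Compound 3 remains a limit of the assay, which leaves the true size of its step open: the limit of > 100000 nM in this assay, at which 1 of the 4 values shown sits.

As far as these compounds go, how an amine, a carboxylic acid or a longer chain at this position would behave remains open.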